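Carboxybenzyl Substitution on Two Indole Cores Against Pannexin-1

The source may hold more compounds than are shown below. What is called first, only, known or untested is meant among the compounds shown, and "the series" means these compounds.

Measured compounds:
compound 1, `O=C(O)c1ccc(Cn2c(C(=O)O)cc3cc(S(=O)(=O)N(Cc4ccccc4)Cc4ccccc4)ccc32)cc1`, 100%
compound 2, `O=C(O)c1cc2cc([N+](=O)[O-])ccc2n1Cc1ccccc1`, 51.3%
compound 3, `O=C(O)c1cc2cc(S(=O)(=O)N(Cc3ccccc3)Cc3ccccc3)ccc2n1Cc1ccccc1`, 41%

All three were tested in an assay on cells (Oocyte) for inhibition of pannexin-1 (Mus musculus), read by voltage clamp, tested at 50 uM, in the presence of a further agent that is not named here; on this read-out lower numbers stand for less inhibition and higher numbers for more inhibition at the one concentration tested (going by the name of the read-out). Compound 3 and compound 1 share one core and differ only by carboxy in place of hydrogen on an aromatic carbon; this change gave a number 59 percentage points higher from compound 3 to compound 1 (beyond the scatter). Compound 2 rests on another core, and the difference between the two cores is not broken down here. Compound 4, `O=C(O)c1ccc(Cn2c(C(=O)O)cc3cc([N+](=O)[O-])ccc32)cc1`, is derived from compound 2 by carboxy in place of hydrogen on an aromatic carbon, the same change as between compound 3 and compound 1. Because a number 59 percentage points higher from compound 3 to compound 1 (beyond the scatter) was large, a step of similar kind is expected from compound 2 to compound 4, namely a number 38.7 percentage points higher from compound 2 to compound 4 (beyond the scatter), so that the number in this assay is expected to be higher for compound 4. Compound 4 is therefore estimated at 90%, with a likely range from 70% to 100%.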

Compound 4, a percentage reported as inhibition, at one concentration (the size of the read-out at that concentration, not a potency): 61%
Compound 4: middle estimate off by 29 percentage points, on the high side; the measured number lies below the stated range.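

On the core of compound 2, carboxy in place of hydrogen on an aromatic carbon gave a number 9.7 percentage points higher from compound 2 to compound 4 (within the scatter) in this assay, so this pair shows no clear effect of the change. The size of the step thus did not carry over from one core to the other: the same change on two cores in this assay, a number 59 percentage points higher (beyond the scatter) from compound 3 to compound 1 and a number 9.7 percentage points higher (within the scatter) from compound 2 to compound 4, 49.3 percentage points apart, beyond the scatter of two such steps. This rests on a single pair per core at one concentration, and it does not show why the two cores part ways or how the change would behave on a further core.

The compounds shown leave open whether an amine or a hydroxyl group in place of the carboxy would give a step of either size. They also leave open whether a longer chain bearing the carboxy would do so.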